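Series notes: the step from compound 3 to compound 4

A few compounds are considered here, and "the series" means these few. Any claim that something is new, unique, unknown or untested is made for them only; others in the source may bear on it.

Measured compounds:
Compound 1 `COc1ccc(C2=NN(c3ccc(-c4ccccc4)nn3)C(c3ccccc3)C2)cc1`: in a functional assay on HepG2 cells (Homo sapiens) for antiproliferative activity, read by MTT assay, with a stated time of 24 h (on this read-out higher numbers stand for weaker inhibition and lower numbers for stronger inhibition), compound 1 gives only the assay limit, > 100000 nM.
Compound 2 `COc1ccc(C2=NN(c3ccc(-c4ccccc4)nn3)C(c3ccc(Cl)cc3)C2)cc1`: in this assay compound 2 again gives only the assay limit, > 100000 nM.
Compound 3 `COc1ccc(C2=NN(c3ccc(-c4ccccc4)nn3)C(c3ccc(C(F)(F)F)cc3)C2)cc1`: in this assay compound 3 likewise gives only the assay limit, > 100000 nM.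

Compound 3 stands at the limit of the assay, and so do the two other values shown (the limit of > 100000 nM in this assay, at which 3 of the 3 values shown sit). No order among compound 1, compound 2 and compound 3 can be read: the steps a step that the two limits leave unreadable from compound 1 to compound 2, a step that the two limits leave unreadable from compound 1 to compound 3 and a step that the two limits leave unreadable from compound 2 to compound 3 are all unreadable, as each runs between two limits.

The unmeasured compound 4 `COc1ccc(C2=NN(c3ccc(-c4ccccc4)nn3)C(c3ccc(OC)cc3)C2)cc1` differs from compound 3 in one place: methoxy in place of trifluoromethyl on an aromatic carbon. Among the measured compounds shown here, the steps that bear on this change are the three exchanges at the same place, chloro or trifluoromethyl for hydrogen, and trifluoromethyl for chloro; none gave a readable size, and none moved any compound off the limit. No step beyond the scatter in this assay is therefore expected, in either direction, and another limit value is the most likely outcome.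

Compound 4 is expected to give about 150000 nM in this assay, with a range from 50000 nM to 500000 nM. The expected step is a step that the limit leaves unreadable from compound 3 to compound 4, within the scatter.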

Compound 4, half-maximal inhibitory concentration: > 100000 nM
Compound 4: no number, only a limit; the forecaster's own chance of this, stated with the estimate: 85%; the middle value lies beyond the limit too.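

In this assay compound 4 gives only a limit, > 100000 nM. Among the compounds shown here, no step from compound 1, compound 2 or compound 3 to compound 4 can be read, as each runs between two limits: the limit of > 100000 nM in this assay, at which 4 of the 4 values shown sit. The compounds shown leave open how these four rank and whether any group at this place gives a measurable value.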